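A few compounds are considered here, and "the series" means these few. Any claim that something is new, unique, unknown or untested is made for them only; others in the source may bear on it.

Measured so far:
compound 1, `COc1ccccc1N1C(=O)CSC1C(=O)NCCCCc1ccccc1`, gives 4%.
compound 2, `COc1ccc(F)cc1N1C(=O)CSC1c1cccc(C(=O)NCCCCc2ccccc2)c1`, gives 62%.

Among the measured compounds shown here, in a functional assay on 143B cells (Homo sapiens) for inhibition, read by CCK-8 assay, with a stated time of 72 h, tested at 1 uM (a higher number here means more inhibition at the concentration tested (going by the name of the read-out), a lower number less inhibition), compound 2 stands highest of the two numbers known. For the measured compounds named here, the nearest number belongs to compound 1, whose reading in this assay lies well below that of compound 2, by a gap beyond the usual scatter; the two compounds differ in more than one place, so no single step between them can be drawn, and only the two values themselves can be compared.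

Compound 3, `Cc1cccc(N2C(=O)CSC2c2cccc(C(=O)NCCCCc3ccccc3)c2)c1`, has not yet been measured in this assay. It differs from compound 2 in one place: 3-methylphenyl in place of 5-fluoro-2-methoxyphenyl on an amide-type nitrogen in a ring. The group that leaves carries one hydrogen-bond acceptor and a fluorine; the group that enters carries neither. Going by the values given here, no measured pair shows the effect of this exchange alone, so the expectation rests on the standing of compound 2 and on the width of the change.

Compound 3 is expected to give about 50% in this assay, within a range from 20% to 78%. This expectation amounts to a step of a number 12 percentage points lower from compound 2 to compound 3 (beyond the scatter), a modest fall that may well sit within the scatter.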

Compound 3, a percentage reported as inhibition, at one concentration (the size of the read-out at that concentration, not a potency): 71%
The estimate for compound 3 lay 21 percentage points below the measured number; low and high end bracket the measured number.
By their numbers in this assay, from the lowest: compound 1; then compounds 2 and 3 (each within the scatter of the next).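

In this assay, among the compounds shown here, placing 3-methylphenyl in place of 5-fluoro-2-methoxyphenyl on the amide-type nitrogen in the ring gives a number 9 percentage points higher from compound 2 to compound 3 (within the scatter), and this is the first exchange at this position that can be read on its own. The reading therefore holds up without the hydrogen-bond acceptor and the fluorine of the group that leaves, so for this pair neither the methoxy group nor the fluorine is needed to keep the inhibition seen at the tested concentration, provided a substituted phenyl ring stays on that nitrogen. No measurement at hand accounts for this outcome.

The pair cannot separate the loss of the methoxy group from the loss of the fluorine, nor show whether the methyl group of compound 3 contributes anything, since both groups differ in several features at once. It also leaves open what an amine or a carboxylic acid on that phenyl ring would do in this assay, or how a longer chain on the amide of compound 3 would read.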